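The compounds below may be only part of what the source reports. "The series", "measured", "known", "first", "only" and "open" are said of these compounds alone.

Measured in a functional assay on HepG2 cells (Homo sapiens) for inhibition, read by MTT assay, with a stated time of 72 h; on this read-out lower numbers stand for stronger inhibition and higher numbers for weaker inhibition:

Compound 1 `Nc1ncnc2c1c(-c1cnc3[nH]ccc3c1)nn2CCCCCCCCC(=O)NO`: 3050 nM
Compound 2 `Nc1nc2cc(-c3nn(CCCC(=O)NO)c4ncnc(N)c34)ccc2o1`: > 50000 nM

Going by the values given here, compound 1, at 3050 nM, holds the only actual number in this set. For compound 2, > 50000 nM is a limit of the assay and not a number. The two values therefore show that compound 1 gave a measurable result in this assay, whereas compound 2 gave only a limit.

The next compound to be tested is compound 3 `Nc1ncnc2c1c(-c1cnc3[nH]ccc3c1)nn2CCCCCCC(=O)NO`. It keeps the core of compound 1 and changes only the chain that ends in the hydroxycarbamoyl group: hydroxycarbamoyl in place of 2-(hydroxycarbamoyl)ethyl on a saturated chain carbon, six bonds along the chain from an aromatic nitrogen. In words, hydroxycarbamoyl takes the place of 2-(hydroxycarbamoyl)ethyl on a saturated chain carbon, six bonds along the chain from an aromatic nitrogen.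

Among the compounds with values here, no measured pair differs at this place alone, so there is no direct precedent for the size of this step. The change is confined to the chain, so a small move towards a lower number is expected, possibly none beyond the usual scatter. The expected change is a 1.5-fold lower number from compound 1 to compound 3 (0.18 log units; within the scatter). For compound 3, the estimated value is 2000 nM, with an expected range from 600 nM to 8000 nM.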

Compound 3, half-maximal inhibitory concentration: 10300 nM
Compound 3: middle estimate off by 5.2-fold (0.71 log units), on the low side; measured number outside the range, above it.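

Going by these compounds alone, with the core of compound 1 held fixed, this pair gives the first direct reading of the chain that ends in the hydroxycarbamoyl group. In this assay, putting hydroxycarbamoyl in place of 2-(hydroxycarbamoyl)ethyl on a saturated chain carbon, six bonds along the chain from an aromatic nitrogen, gives a 3.4-fold higher number from compound 1 to compound 3 (0.53 log units; beyond the scatter), so the shorter chain is the weaker of the two and chain length at this position does change the read-out. The size of this step can be read in full, because compound 3 still gives a real number and stays clear of the ceiling of the read-out: the limit of > 50000 nM in this assay, at which 1 of the 3 values shown sits.

Going by these compounds, a single step between two chain lengths gives a direction for this one pair, not a trend, so it remains open whether inhibition would keep falling with a still shorter chain or would improve with a longer chain than that of compound 1. On these data alone, it is equally open how the result would change if a carboxylic acid or an amine stood at the end of the chain in place of the hydroxycarbamoyl group.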